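Morpholine to thiomorpholine on the thiocarbonyl carbon

The source may hold more compounds than are shown below. What is called first, only, known or untested is meant among the compounds shown, and "the series" means these compounds.

Compound 2 `Cc1ccnc(/C(N)=N/NC(=S)N2CCOCC2)c1` stands highest of the two numbers in a functional assay on A-375 cells (Homo sapiens) for cytotoxicity, read by MTT assay, with a stated time of 72 h, tested at 100 uM (on this read-out higher numbers stand for more inhibition of growth at the one concentration tested and lower numbers for less inhibition of growth), with 90.6%; its nearest neighbour, compound 1 `N/C(=N\NC(=S)N1CCOCC1)c1ccccn1`, gives 14%. Within the data shown here, the one measured step, a number 76.6 percentage points higher from compound 1 to compound 2 (beyond the scatter), concerns the aromatic ring and not the ring on the thiocarbonyl carbon. Compound 3 `Cc1ccnc(/C(N)=N/NC(=S)N2CCSCC2)c1` carries thiomorpholin-4-yl in place of morpholin-4-yl on a thiocarbonyl carbon. Among the measured compounds shown here, no measured step bears on this exchange, so for compound 3 no step beyond the scatter is expected in this assay, which means an expected a number 5.6 percentage points lower from compound 2 to compound 3 (within the scatter). Compound 3 is therefore estimated at 85%, with a range from 55% to 98%.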

Compound 3, percent growth inhibition at one concentration: 89.9%
Beside the measured number, compound 3's estimate is 4.9 percentage points below it; the range from low to high includes it.
By their numbers in this assay, from the lowest: compound 1; then compounds 3 and 2 (each within the scatter of the next).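

In this assay the step to thiomorpholin-4-yl in place of morpholin-4-yl on a thiocarbonyl carbon is a number 0.7 percentage points lower from compound 2 to compound 3 (within the scatter) and so does not separate the two compounds. This place on the methyl-bearing compounds therefore tolerates sulfur in place of the ring oxygen, at least at this one concentration. No evidence at hand accounts for this result.

As far as these compounds go, whether a piperazine or an open-chain dimethylamino group would hold up at this place remains open. So does whether thiomorpholin-4-yl would behave alike on compound 1, without the methyl.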